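This account rests on a few compounds, and the source may have more. Where it says the series, first, only, none or still open, it means among the compounds named here.

In an ADME assay on microsomes from liver (Rattus norvegicus) for metabolic stability (on this read-out lower numbers stand for slow clearance and higher numbers for fast clearance), compound 1 `CN1[C@@H](c2ccc(OCc3ccccc3F)cc2)CC[C@H]1C(N)=O` gives 1.3 mL.min-1.g-1 and compound 2 `NC(=O)[C@@H]1CC[C@H](c2ccc(OCc3ccc(F)cc3)cc2)N1` gives 1.8 mL.min-1.g-1. These two values lie within the usual scatter of repeated measurements, so the pair cannot be told apart on this read-out, and compound 2 has no measured neighbour clearly separated from it. Compound 3 `NC(=O)[C@@H]1CC[C@H](c2ccc(OCc3cccc(F)c3)cc2)N1` differs from compound 2 in one place: 3-fluorophenyl in place of 4-fluorophenyl on a saturated chain carbon bound to an oxygen on an aromatic ring. It carries 3-fluorophenyl in place of 4-fluorophenyl on a saturated chain carbon bound to an oxygen on an aromatic ring, so it has the same atoms, joined differently. Going by the values given here, no measured pair shows what such a swap does. Starting from compound 2 at 1.8 mL.min-1.g-1, no step beyond the scatter is expected in this assay, and no direction can be favoured. The estimate amounts to a step of a 1.1-fold higher number from compound 2 to compound 3 (0.05 log units; within the scatter), expected to stay within the scatter. For compound 3 the expected value is 2 mL.min-1.g-1, with a range from 1 mL.min-1.g-1 to 4 mL.min-1.g-1.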

Compound 3, intrinsic clearance in microsomes: < 0.5 mL.min-1.g-1
Compound 3: a limit, no number; the forecaster's own chance of this, stated with the estimate: 5%; at least 4.0-fold (0.60 log units) between middle value and limit.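

In this assay, 3-fluorophenyl in place of 4-fluorophenyl on a saturated chain carbon bound to an oxygen on an aromatic ring gives an at least 3.6-fold lower number from compound 2 to compound 3 (0.55 log units; beyond the scatter). This shows that, for this pair, the read-out responds to where the fluorine sits on the phenyl ring, even though both compounds have the same atoms. The result for compound 3 is a limit of the assay and not a number: the limit of < 0.5 mL.min-1.g-1 in this assay, at which 1 of the 3 values shown sits.

As far as these compounds go, it remains open how a plain phenyl group, or a chlorine atom or methoxy group in place of the fluorine, would read in this assay. Also open, from the compounds shown here alone, is whether the same swap would give a similar step on the core of compound 1, so this single pair sets no general rule.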